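The source may report more compounds than this note shows. Statements on the series, on what has been measured and on what is new or still open speak of the compounds shown alone.

Measured compounds:
- compound 1, `NCCCOc1ccc(CNc2nc3ccc(Oc4ccc(O)cc4)cc3s2)cc1`: 205000 nM
- compound 2, `CN(Cc1ccc(OCCCNC(=N)N)cc1)c1nc2ccc(Oc3ccc(O)cc3)cc2s1`: 432000 nM
- compound 3, `N=C(N)NCCCOc1ccc(CNc2nc3ccc(Oc4ccc(F)cc4)cc3s2)cc1`: 244000 nM

In an assay on SH-SY5Y cells for inhibition of Voltage-dependent N-type calcium channel subunit alpha-1B (Homo sapiens), read by FLIPR and calcium flux, with stated times of 600 s and 300 s, in the presence of a further agent that is not named here (on this read-out lower numbers stand for stronger inhibition and higher numbers for weaker inhibition), compound 1 gives 205000 nM, compound 2 gives 432000 nM and compound 3 gives 244000 nM. Compound 3 stands second highest of the three numbers; its nearest neighbour is compound 1 and its furthest is compound 2, and both of these lie within the usual scatter of compound 3, so the three numbers are not separated from one another. All three are weak on this read-out.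

Compound 4, `N=C(N)NCCCOc1ccc(CNc2nc3ccc(Oc4ccc(O)cc4)cc3s2)cc1`, has not yet been measured. It differs from compound 3 by hydroxy in place of fluoro on an aromatic carbon. Compound 1 carries the same hydroxy group on that ring and sits within the scatter of compound 3, which gives no ground to expect a shift beyond the scatter. The step from compound 3 to compound 4 is therefore expected to be small, a 1.1-fold lower number from compound 3 to compound 4 (0.04 log units; within the scatter), with no clear direction. Compound 4 is estimated at 220000 nM, in the range 100000 nM to 480000 nM.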

Compound 4, half-maximal inhibitory concentration: 253000 nM
Estimate against measurement, compound 4: 1.2-fold (0.06 log units) below, within the range that was stated.
By their numbers in this assay, from the lowest: compounds 1, 3, 4 and 2 (each within the scatter of the next, the first and the last beyond it).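

In this assay, among these compounds, the change from 4-fluorophenoxy to 4-hydroxyphenoxy gives a 1.0-fold higher number from compound 3 to compound 4 (0.02 log units; within the scatter) and so does not separate the pair, which is the first direct reading of this swap at this place on the ring. The two other single changes read alike: hydrogen in place of methyl on the nitrogen gives a 1.7-fold lower number from compound 2 to compound 4 (0.23 log units; within the scatter) and the group of 3 heavy atoms in place of a hydrogen atom on the amine nitrogen gives a 1.2-fold higher number from compound 1 to compound 4 (0.09 log units; within the scatter) and neither sets compound 4 apart. No measured evidence here bears on these results.

As far as these compounds go, whether an amine or a carboxylic acid at this place on the ring would move the number beyond the scatter stays open. So does the effect of a longer chain in place of the one carrying the terminal group.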